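From a Carbamoyl Chain to an Ethoxycarbonyl Group

The compounds below may be only part of what the source reports. "The series", "measured", "known", "first", "only" and "open" are said of these compounds alone.

In an ADME assay on L929 cells (Mus musculus) for cytotoxicity, read by resazurin assay, with a stated time of 48 h (a lower number here means that less compound is tolerated, a higher number that more compound is tolerated), compound 1 (`O=c1c2cc([N+](=O)[O-])ccc2n(CCCBr)n1Cc1ccccc1`) gives 25200 nM as a true reading. Compound 2 (`O=C(O)CCCn1c2ccc([N+](=O)[O-])cc2c(=O)n1Cc1ccccc1`) gives > 256000 nM as a limit of the assay. Compound 3 (`NC(=O)CCCn1c2ccc([N+](=O)[O-])cc2c(=O)n1Cc1ccccc1`) gives > 256000 nM as a limit too. Compound 4 (`CCOC(=O)n1c2ccc([N+](=O)[O-])cc2c(=O)n1Cc1ccccc1`) carries ethoxycarbonyl in place of 3-carbamoylpropyl on an aromatic nitrogen. The nearest evidence concerns the chain end: carboxy in place of bromo gave an at least 10-fold higher number from compound 1 to compound 2 (1.00 log units; beyond the scatter) and carbamoyl in place of bromo gave an at least 10-fold higher number from compound 1 to compound 3 (1.00 log units; beyond the scatter) on the same core. Amino in place of hydroxy gave a step that the two limits leave unreadable from compound 2 to compound 3 as well. None of these steps replaces the whole group, so they guide only loosely. In this assay a lower number is expected, with the estimated step being an at least 3.6-fold lower number from compound 3 to compound 4 (0.56 log units; beyond the scatter) in size and direction. Compound 4 is estimated at 70000 nM with an expected range from 15000 nM to 256000 nM overall.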

Compound 4, concentration lethal to 50% of the cells: 122000 nM
Estimate against measurement, compound 4: 1.7-fold (0.24 log units) below, and the stated range covers the measured number.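

In this assay, replacing the whole chain on the aromatic nitrogen, rather than only its end, also moves the number beyond the scatter, with an at least 2.0-fold lower number from compound 3 to compound 4 (0.32 log units; beyond the scatter) and an at least 2.0-fold lower number from compound 2 to compound 4 (0.32 log units; beyond the scatter). Against the bromo chain, the ethoxycarbonyl group gives a 4.8-fold higher number from compound 1 to compound 4 (0.68 log units; beyond the scatter). Unlike the carboxy and carbamoyl chains, it therefore gives a true reading on this nitrogen.

From the compounds shown here alone, the full size of the first two steps stays open, since compound 2 and compound 3 each sit at a limit: the limit of > 256000 nM in this assay, at which 2 of the 4 values shown sit. Whether an amine or a longer ester chain here would stay nearer compound 4 or compound 1 also remains open.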